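The compounds below may be only part of what the source reports. "The series", "measured", "known", "first", "only" and "open" are said of these compounds alone.

Measured so far in an ADME assay on microsomes from liver (Homo sapiens) for metabolic stability, with a stated time of 30 min, tested at 1 uM; a higher number here means that more of the compound is left, a lower number that less of the compound is left:
- compound 2, `CCN(CC)CCN1CCN(C(=O)COCCN(C)S(=O)(=O)c2c(C)cc(OC)cc2C)CC1`, gives 73%
- compound 3, `COc1cc(C)c(S(=O)(=O)N(C)CCOCC(=O)N2CCN([C@H]3CN4CCC3CC4)CC2)c(C)c1`, gives 26%
- compound 1, `CN(Cc1ccc(C2=NCCN2)cc1)C(=O)COCCN(C)S(=O)(=O)c1c(Cl)cccc1Cl`, gives "not determined" (no result reported)

Compound 1 therefore stands nowhere on the numbers shown: no result has been reported for it in this assay, and nothing about its own stability can be read off the series. Going by the values given here, the only measured step, a number 47 percentage points lower from compound 2 to compound 3 (beyond the scatter), concerns a change on an amine nitrogen in a ring at the far end of the shared core; it does not touch the sulfonyl end and so does not bear on the change at hand.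

Compound 4, `CN(Cc1ccc(C2=NCCN2)cc1)C(=O)COCCN(C)S(=O)(=O)c1c(F)cccc1F`, differs from compound 1 by 2,6-difluorophenyl in place of 2,6-dichlorophenyl on a sulfonyl sulfur. Among the compounds with values here, no step involves a change at this position, and no value exists for compound 1, so there is no measured reference for the direction or size of the move in this assay. Within the data shown here, what can be said is only that the two compounds carrying the sulfonamide motif, compound 2 and compound 3, span a wide range in this assay, so the figure for compound 4 is taken as lying within that span. The percent remaining for compound 4 is estimated at 45%, with a range from 15% to 80%.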

Compound 4, percent of the compound remaining: 87%
Compound 4: middle estimate off by 42 percentage points, on the low side, outside the stated range (above it).
By their numbers in this assay, from the lowest: compound 3; then compound 2; then compound 4.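

In this assay compound 4 gives 87% while compound 1 gives "not determined" (no result reported), so no step can be read between compound 1 and compound 4. The compounds shown leave open how 2,6-difluorophenyl compares with 2,6-dichlorophenyl on a sulfonyl sulfur in this assay. Nothing at hand bears on the result for compound 4.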